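Cyclopropyl for isobutyl at the five-membered ring of compound 2

The compounds below may be only part of what the source reports. "The series", "measured", "known", "first", "only" and "open" are said of these compounds alone.

Measured so far in a functional assay on cells for antagonist activity at prostaglandin E2 receptor EP1 subtype (Rattus norvegicus), read by fluorescence and calcium flux, with a stated time of 60 s; a higher number here means a weaker inhibitor, a lower number a stronger inhibitor:
- compound 1, `COc1ccc(-c2nn3cc(Cl)ccc3c2Cc2cccc(C(=O)O)n2)cc1`: 5400 nM
- compound 2, `CC(C)Cc1nn2cc(Cl)ccc2c1Cc1cccc(C(=O)O)n1`: 200 nM

Compound 2 holds the lowest of the two numbers in this assay; its nearest neighbour is compound 1, and the step from that compound is a 27-fold lower number from compound 1 to compound 2 (1.43 log units; beyond the scatter) — a large move that comes from putting a chain in place of the aryl group on the core.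

Compound 3 is `O=C(O)c1cccc(Cc2c(C3CC3)nn3cc(Cl)ccc23)n1`. It differs from compound 2 in one place: cyclopropyl in place of isobutyl on an aromatic carbon. Among the compounds with values here, the only measured step that bears on this is the one above, and it compares an aryl group with a chain, not one chain with a ring of carbon only. Within the data shown here, the change here keeps a non-aromatic carbon group at the same site, so a move as large as the one from compound 1 to compound 2 is not expected, in either direction.

Compound 3 is therefore estimated to give roughly 400 nM in this assay, within 100 nM to 1600 nM, which corresponds to an expected step of a 2.0-fold higher number from compound 2 to compound 3 (0.30 log units; within the scatter).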

Compound 3, half-maximal inhibitory concentration: 1500 nM
Estimate against measurement, compound 3: 3.8-fold (0.57 log units) below; low and high end bracket the measured number.
By their numbers in this assay, from the lowest: compound 2; then compound 3; then compound 1.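

In this assay this position on the five-membered ring distinguishes between two non-aromatic carbon groups, and a 7.5-fold higher number from compound 2 to compound 3 (0.88 log units; beyond the scatter) shows that replacing the aryl group with a non-aromatic carbon group does not by itself deliver the full gain seen with isobutyl. Cyclopropyl still keeps part of that gain, as a 3.6-fold lower number from compound 1 to compound 3 (0.56 log units; beyond the scatter) shows, so the three groups at this site give three separate levels, with isobutyl in compound 2 lowest, cyclopropyl in compound 3 in the middle and 4-methoxyphenyl in compound 1 highest. Nothing available explains why isobutyl and cyclopropyl differ at this site.

With only one chain and one carbon ring at this site, the compounds cannot separate the effect of the ring from that of the count of carbon atoms, and a cyclobutyl, a cyclopentyl or a straight propyl chain would bear on that. Going by these compounds, whether a longer chain such as n-pentyl gives a lower number than isobutyl, or whether an ether oxygen or an amine in the chain is compatible with the number of compound 2, also stays open.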